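Chloro for Fluoro: What to Expect of Compound 4

This account rests on a few compounds, and the source may have more. Where it says the series, first, only, none or still open, it means among the compounds named here.

Of the compounds shown here, three have been measured in an assay on U2OS cells for activation of nuclear factor erythroid 2-related factor 2 (Homo sapiens), read by beta-arrestin recruitment, with a stated time of 6 h; a higher number here means that more compound is needed for the effect, a lower number that less compound is needed. Compound 1 `O=S(=O)(/C=C\c1ncccc1F)c1ccccc1Cl` gives 583 nM. Compound 2 `O=S(=O)(/C=C\c1ncccc1Cl)c1ccccc1Cl` gives 1100 nM in this assay. Compound 3 `O=S(=O)(/C=C/c1ccncc1)c1ccccc1F` gives 760 nM in this assay. All three numbers lie within the usual scatter of one another, so none of them can be called stronger or weaker than the others. Compound 3 and compound 1 differ in more than one place, and the difference between the two cores is not broken down here.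

Compound 1 and compound 2 differ in a single place: chloro in place of fluoro on an aromatic carbon. This change gave a 1.9-fold higher number from compound 1 to compound 2 (0.28 log units; within the scatter).

Compound 4 `O=S(=O)(/C=C/c1ccncc1)c1ccccc1Cl` has not yet been measured. It differs from compound 3 in one place: chloro in place of fluoro on an aromatic carbon. Within the data shown here, this is the same kind of change as the one from compound 1 to compound 2, but not the same change: in compound 1 the fluoro sits on a six-membered aromatic ring with 1 nitrogen, two atoms from the ring nitrogen, whereas in compound 3 it sits on a six-membered aromatic ring of carbon only; in both cases it is ortho to a large group.

Because the earlier example of this kind of change gave a 1.9-fold higher number from compound 1 to compound 2 (0.28 log units; within the scatter), the step to compound 4 is expected to be a 1.6-fold higher number from compound 3 to compound 4 (0.20 log units; within the scatter) in this assay. Compound 4 is therefore estimated at 1200 nM in this assay. Among the measured compounds shown here, the expected range for compound 4 runs from 500 nM to 3000 nM, wide because it rests on the single earlier step of a 1.9-fold higher number from compound 1 to compound 2 (0.28 log units; within the scatter), which itself lay within the scatter.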

Compound 4, half-maximal effective concentration: 781 nM
Estimate against measurement, compound 4: 1.5-fold (0.19 log units) above; measured number inside the range.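

On the six-membered aromatic ring of carbon only, chloro in place of fluoro gave a 1.0-fold higher number from compound 3 to compound 4 (0.01 log units; within the scatter) in this assay, so on this core the exchange leaves no effect that can be told apart from the ordinary spread of repeated measurements. Set beside the earlier example on the other core, the new step cannot be distinguished from it: the same change on two cores in this assay, a 1.9-fold higher number (0.28 log units; within the scatter) from compound 1 to compound 2 and a 1.0-fold higher number (0.01 log units; within the scatter) from compound 3 to compound 4, 1.8-fold (0.26 log units) apart, within the scatter of two such steps. This shows that the change stayed small on both cores and gives no sign that the core alters its outcome, but it does not show that the change is truly without effect, nor that it would behave alike on a third core, as two steps are few and both lie within the scatter.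

At this place, the compounds shown carry only fluoro and chloro, so it remains open what bromo, a methoxy group, an amine or a carboxylic acid would do to the number. On these data alone, both steps also come from this one cell-based read-out, so whether the exchange matters in any other kind of test remains open too.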